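The compounds below may be only part of what the source reports. "The series", "measured", "known", "first", "only" and "open" are said of these compounds alone.

Measured compounds:
Compound 1 `O=C1CCCCCC1C1CC(=O)N(c2ccccc2)C1=O`: 18400 nM
Compound 2 `Cc1ccc(C(=O)CC2CC(=O)N(c3ccc(S(N)(=O)=O)cc3)C2=O)cc1`: 860 nM
Compound 3 `CC(=O)C(C)(C)C1CC(=O)N(c2ccccc2)C1=O`: 53500 nM

All three were run in an assay on cells (1-87 tumor cell line) for inhibition of Polyunsaturated fatty acid 5-lipoxygenase (Homo sapiens), with a stated time of 5 min; a lower number here means a stronger inhibitor, a higher number a weaker inhibitor. Compound 2 gives the lowest number of the three; compound 1 lies higher by a margin beyond the scatter, and compound 3 lies higher still, also beyond the scatter. Going by the values given here, no pair among the measured compounds differs in a single place, so no measured step is available to calibrate the change considered here.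

Compound 4 `NS(=O)(=O)c1ccc(N2C(=O)CC(CC(=O)c3ccc(Cl)cc3)C2=O)cc1` has not yet been measured. It differs from compound 2 in one place: chloro in place of methyl on an aromatic carbon. Among the compounds with values here, nothing among the measured compounds speaks to this particular exchange, so the expectation rests on compound 2 alone. The step is expected to be modest, a 1.1-fold lower number from compound 2 to compound 4 (0.06 log units; within the scatter), with no direction claimed beyond the usual scatter of this assay. Compound 4 is therefore estimated at 750 nM in this assay, with a range from 250 nM to 2500 nM.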

Compound 4, half-maximal inhibitory concentration: 12600 nM
For compound 4 the middle estimate is 17-fold (1.23 log units) below the measured one; measured number above the stated range.
By their numbers in this assay, from the lowest: compound 2; then compounds 4 and 1 (each within the scatter of the next); then compound 3.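

In this assay the exchange on this aromatic carbon, para to a large group, is far from neutral: chloro in place of methyl gives a 15-fold higher number from compound 2 to compound 4 (1.17 log units; beyond the scatter) and shows that this position of the series responds strongly to a change of a single heavy atom. The count of hydrogen-bond donors and acceptors is the same on both sides of the exchange, so the low number of compound 2 depends on the methyl here, at least when set against chloro. Nothing shown accounts for the size of this step.

A single step cannot tell whether methyl is favoured or chloro disfavoured, and hydrogen, fluoro, methoxy or ethyl at the same place would be needed to separate the two. Also open, from the compounds shown here alone, is whether the exchange gives a step of this size when the sulfonamide is replaced by a carboxylic acid.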